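Second fluoro on the aryl ring of compound 2

This account rests on a few compounds, and the source may have more. Where it says the series, first, only, none or still open, it means among the compounds named here.

Among the measured compounds shown here, compound 2 `N=C(NCCCc1c[nH]cn1)NCCC(c1ccc(F)cc1)c1ccccn1` gives the lowest number of the two measured so far: in a functional assay on ileum for antagonist activity at histamine H1 receptor (Cavia porcellus) (a lower number here means tighter binding, a higher number weaker binding), compound 2 gives 22.4 nM. Compound 1 `COc1ccc(C(CC/N=C(\N)NCCCc2c[nH]cn2)c2ccccn2)cc1` stands clearly weaker in this assay, where compound 1 gives 269 nM, a gap beyond the scatter.

Compound 3 `N=C(NCCCc1c[nH]cn1)NCCC(c1ccc(F)c(F)c1)c1ccccn1` differs from compound 2 by fluoro in place of hydrogen on an aromatic carbon. For the measured compounds named here, no measured pair shows this change, so the size of the step is an estimate only; the expected step is a 1.1-fold higher number from compound 2 to compound 3 (0.05 log units; within the scatter), that is none beyond the scatter in this assay. Compound 3 is therefore estimated at 25 nM, with a range from 8 nM to 80 nM.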

Compound 3, dissociation constant: 85.1 nM
Beside the measured number, compound 3's estimate is 3.4-fold (0.53 log units) below it, and the stated range ends below it.
By their numbers in this assay, from the lowest: compound 2; then compound 3; then compound 1.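

Among the compounds shown here, the measurement in this assay gives a 3.8-fold higher number from compound 2 to compound 3 (0.58 log units; beyond the scatter), the first step that differs in one place. The change in this step is 4-fluorophenyl to 3,4-difluorophenyl. This position, ortho to a fluoro group, therefore does not take a second fluoro without a loss, though the step is modest. Nothing available accounts for this rise in the number.

Open, going by these compounds, is whether chloro or methyl at this position gives a step of similar size, and whether hydrogen is the best group there.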